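Working notes: amino to methoxy step on a shared core

The compounds below may be only part of what the source reports. "The series", "measured", "known", "first", "only" and "open" are said of these compounds alone.

Measured so far:
compound 1 `Oc1ccccc1/C=C/c1ccccc1O` gives 23 ug/mL in a functional assay on MCF7 cells (Homo sapiens) for inhibition, read by MTT assay, with a stated time of 2 days; on this read-out higher numbers stand for weaker inhibition and lower numbers for stronger inhibition
compound 2 `Oc1cccc(/C=C/c2ccccc2O)c1` gives 20.1 ug/mL
compound 3 `Nc1ccccc1/C=C/c1cccc(O)c1` gives 17 ug/mL

Compound 3 sits at the low end of the three numbers, but compound 2 and compound 1 both lie within the scatter of it. Compound 4 `COc1ccccc1/C=C/c1cccc(O)c1` is not yet measured; the change is methoxy in place of amino on an aromatic carbon. Among the measured compounds shown here, the only measured step at this position is the hydroxy-to-amino swap, a 1.2-fold lower number from compound 2 to compound 3 (0.07 log units; within the scatter), which is within the scatter. For the measured compounds named here, no amino-to-methoxy step has been measured, so the expectation rests on that one small step alone. In this assay the step is expected to be a 1.2-fold higher number from compound 3 to compound 4 (0.07 log units; within the scatter), nothing beyond the scatter. Compound 4 is therefore estimated at 20 ug/mL, with a range of 10 ug/mL to 40 ug/mL.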

Compound 4, half-maximal inhibitory concentration: 24.3 ug/mL
Beside the measured number, compound 4's estimate is 1.2-fold (0.08 log units) below it, within the range that was stated.
By their numbers in this assay, from the lowest: compounds 3, 2, 1 and 4 (each within the scatter of the next).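

In this assay, the first amino-to-methoxy step reads a 1.4-fold higher number from compound 3 to compound 4 (0.16 log units; within the scatter), and methylating the hydroxy oxygen at the same position reads a 1.2-fold higher number from compound 2 to compound 4 (0.08 log units; within the scatter). Hydroxy, amino and methoxy on this aromatic carbon therefore cannot be separated on these numbers, so the position shows no measurable preference among the three groups so far. Nothing available offers an explanation for these steps.

As far as these compounds go, whether a carboxylic acid or a longer chain such as ethoxy at this position would give a step beyond the scatter remains open.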